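Aryl exchange on the same nitrogen: estimating compound 3

This account rests on a few compounds, and the source may have more. Where it says the series, first, only, none or still open, it means among the compounds named here.

Compound 2 `COc1cc(NC(=O)Nc2cc(Nc3ccc(Br)cc3OC)ncn2)cc(OC)c1` stands lowest of the two numbers in hand. In a functional assay on NCI-H226 cells (Homo sapiens) for inhibition, read by MTT assay, with a stated time of 48 h, tested at 10 uM (a higher number here means more inhibition at the concentration tested (going by the name of the read-out), a lower number less inhibition), compound 2 gives 25.7%, and compound 1 `COc1cc(NC(=O)Nc2cc(Nc3cccc(C(C)(C)C)c3)ncn2)cc(OC)c1` gives 40%. Among the compounds with values here, the single measured step, a number 14.3 percentage points lower from compound 1 to compound 2 (beyond the scatter), changes the group on the same nitrogen that is changed again here. Compound 3 `COc1cc(NC(=O)Nc2cc(Nc3ccc(OC)c(I)c3)ncn2)cc(OC)c1` differs from compound 2 by 3-iodo-4-methoxyphenyl in place of 4-bromo-2-methoxyphenyl on a nitrogen on an aromatic ring. Within the data shown here, only that one step bears on this place, and it was modest; it shows that exchanging the group on this nitrogen moved the read-out beyond the scatter, but it gives no direction for a new group that carries iodine and a methoxy group where compound 2 carried bromine and a methoxy group. A modest step in either direction, or none beyond the scatter, is therefore expected. The estimate for compound 3 is 30%, with a range from 12% to 50%. The step expected from this change is a number 4.3 percentage points higher from compound 2 to compound 3 (within the scatter).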

Compound 3, a percentage reported as inhibition, at one concentration (the size of the read-out at that concentration, not a potency): 40.1%
Compound 3: middle estimate off by 10.1 percentage points, on the low side; low and high end bracket the measured number.
By their numbers in this assay, from the lowest: compound 2; then compounds 1 and 3 (each within the scatter of the next).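

In this assay, the exchange on this nitrogen can also raise the read-out: a number 14.4 percentage points higher from compound 2 to compound 3 (beyond the scatter) and so reverses a drop of about the same size seen earlier, showing that the lower number belongs to 4-bromo-2-methoxyphenyl and not to every replacement of 3-(tert-butyl)phenyl. Meanwhile, a number 0.1 percentage points higher from compound 1 to compound 3 (within the scatter), so 3-iodo-4-methoxyphenyl and 3-(tert-butyl)phenyl cannot be told apart in this read-out. Nothing given here accounts for these differences.

The change from 4-bromo-2-methoxyphenyl to 3-iodo-4-methoxyphenyl alters the halogen and the place of the methoxy group together, so the compounds shown leave open which of the two goes with the higher number. Also open, on these data alone, is how an aryl group carrying an amine or a carboxylic acid would read on this nitrogen.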